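Compound 1 and the loss of its cyano group

The source may report more compounds than this note shows. Statements on the series, on what has been measured and on what is new or still open speak of the compounds shown alone.

In a functional assay on DU-145 cells (Homo sapiens) for inhibition (on this read-out higher numbers stand for weaker inhibition and lower numbers for stronger inhibition), compound 1 (`CCOc1ccc(Br)cc1-c1cc(Nc2ccc(C#N)cc2)nc(N)n1`) gives 400 nM as its reading. In this assay compound 2 (`Cc1ccc(Cl)cc1-c1cc(Nc2cccc(Br)c2)nc(N)n1`) gives 400 nM as well, so the two stand level and together hold the highest number of the three measured compounds. Compound 3 (`Cc1ccc(Br)cc1-c1cc(Nc2ccc(Cl)cc2)nc(N)n1`) reads 100 nM and lies below compound 1 by more than the scatter.

The next compound to be read is compound 4 (`CCOc1ccc(Br)cc1-c1cc(Nc2ccccc2)nc(N)n1`). It differs from compound 1 in one place only: hydrogen in place of cyano on an aromatic carbon, para to a large group, which turns 4-cyanophenyl into phenyl (hydrogen in place of cyano on an aromatic carbon). The rest of the structure stays as it is.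

Among the compounds with values here, no two measured compounds differ in a single place, so the series offers no direct size for this change. Compound 1 at 400 nM is the closest anchor, and the expectation therefore stays near it. The expected step of a 1.5-fold higher number from compound 1 to compound 4 (0.18 log units; within the scatter) is one that stays within the scatter, with a slight lean towards a higher number and so weaker inhibition. For compound 4 the estimated value is 600 nM (expected range from 200 nM to 2000 nM).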

Compound 4, half-maximal inhibitory concentration: > 1000 nM
Compound 4 ended at the assay's limit (the forecaster's own chance of this, stated with the estimate: 5%); at least 1.6-fold (0.22 log units) between middle value and limit.
By their numbers in this assay, from the lowest: compound 3; then compounds 1 and 2 (each within the scatter of the next). At a limit, above all of these: compound 4.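

Replacing cyano with hydrogen on the aromatic carbon, which turns 4-cyanophenyl into phenyl, gives an at least 2.5-fold higher number from compound 1 to compound 4 (0.39 log units; beyond the scatter) in this assay. Within the data shown here, this is the only single-place step so far, and it gives the cyano group a measured role: with the rest of compound 1 unchanged, losing it weakens inhibition by more than the scatter. Compound 4 stands at a limit of the assay, so the step sets only a lower bound on the loss, and its full size stays unknown: the limit of > 1000 nM in this assay, at which 1 of the 4 values shown sits.

Still open, from the compounds shown here alone, is whether inhibition at this place depends on cyano itself, or whether another group, such as an amine, a carboxylic acid or a methoxy group, would hold it at the level of compound 1 or lose it as hydrogen does. Also open is whether the same change gives a step of similar size on the shared core when methyl stands in place of ethoxy, as no such pair is among the compounds shown.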